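The source may report more compounds than this note shows. Statements on the series, on what has been measured and on what is new or still open speak of the compounds shown alone.

The measured compounds:

compound 1, `CCc1cc(S(=O)(=O)N2C[C@H](c3ccccc3)NC2=O)ccc1NC(=O)OC(C)C`: 60 nM
compound 2, `Cc1cc(S(=O)(=O)N2C(=O)N[C@@H](c3ccccc3)C2C)ccc1NC(=O)c1ccc(N)cc1`: > 10000 nM

Both were tested in a functional assay on A549 cells (Homo sapiens) for cytotoxicity, read by MTT assay; a higher number here means a weaker inhibitor, a lower number a stronger inhibitor. Compound 1 gives 60 nM in this assay. For compound 2 the reported value, > 10000 nM, is a limit of the assay and not a number. Among the compounds with values here, the two compounds differ in several places at once, so no single step between them is known; their two values show only that compound 1 lies well inside the measured range while compound 2 does not. Of the values shown, (the limit of > 10000 nM in this assay, at which 1 of the 2 values shown sits).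

Compound 3, `Cc1cc(S(=O)(=O)N2C(=O)N[C@@H](c3ccccc3)C2C)ccc1NC(=O)c1ccc([N+](=O)[O-])cc1`, has not yet been measured. It differs from compound 2 in one place: nitro in place of amino on an aromatic carbon. Within the data shown here, no step between measured compounds speaks to a change of this kind, so the expectation rests on where compound 2 stands. Compound 2 sits at the limit, and a modest move in either direction would leave a compound there as well. The data give no reason to expect a move large enough to reach the measured range. The expected step is a step that the limit leaves unreadable from compound 2 to compound 3, none beyond the scatter. Compound 3 is therefore estimated at 15000 nM, between 4000 nM and 60000 nM.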

Compound 3, half-maximal inhibitory concentration: > 10000 nM
Compound 3: a limit, no number; the forecaster's own chance of this, stated with the estimate: 80%; the middle value does not contradict the limit.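

Compound 3, like compound 2, gives only a limit of the assay and no number in this assay, so no step between the two can be read: the limit of > 10000 nM in this assay, at which 2 of the 3 values shown sit.

The compounds shown leave open whether nitro in place of amino changes the activity at all, and which of the several differences from compound 1 matters.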